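A few compounds are considered here, and "the series" means these few. Any claim that something is new, unique, unknown or untested is made for them only; others in the source may bear on it.

In an in vitro ADME assay on microsomes from liver (Homo sapiens) for pharmacokinetics, read by LC-MS (on this read-out higher numbers stand for fast clearance and lower numbers for slow clearance), compound 2 (`Cc1nc2c(F)cccc2n1-c1ccc(C(=O)NC2CC2)s1`) gives < 4 mL/min/kg, which is a limit of the assay and not a number. Compound 3 (`Cc1nc2c(C#N)cccc2n1-c1ccc(C(=O)NC2CC2)s1`) gives < 4 mL/min/kg, which is also a limit. The picture for compound 2 therefore rests on (the limit of < 4 mL/min/kg in this assay, at which 2 of the 3 values shown sit). Among the measured compounds shown here, the only measured step is a step that the two limits leave unreadable from compound 2 to compound 3, and it concerns a different change, so it gives no size to carry over.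

Compound 4 (`Cc1cc(F)c2nc(C)n(-c3ccc(C(=O)NC4CC4)s3)c2c1`) differs from compound 2 by one change: methyl in place of hydrogen on an aromatic carbon. The nearest guide is compound 1 (`Cc1ccc2nc(C)n(-c3ccc(C(=O)NC4CC4)s3)c2c1`), which also carries a methyl group on the shared core but has no fluoro group. In this assay, compound 1 gives 10 mL/min/kg. For the measured compounds named here, with that value as the only measured number, a modest rise in clearance is expected, and compound 4 could still read as a limit. The expected size of the change is an at least 1.2-fold higher number from compound 2 to compound 4 (0.09 log units; that floor lies within the scatter). For compound 4 the estimated clearance is 5 mL/min/kg, with an expected range from 3 mL/min/kg to 10 mL/min/kg.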

Compound 4, clearance: 12 mL/min/kg
Estimate against measurement, compound 4: 2.4-fold (0.38 log units) below; the measured number lies above the stated range.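

In this assay, among the compounds shown here, the earlier compounds gave no readable step, whereas methyl in place of hydrogen on this aromatic carbon, meta to a fluoro group and para to a fused ring, gives an at least 3.0-fold higher number from compound 2 to compound 4 (0.47 log units; beyond the scatter). That size is a floor with no upper bound, because compound 2 stands at a limit of the assay and not at a number: the limit of < 4 mL/min/kg in this assay, at which 2 of the 4 values shown sit. With the methyl group present, the fluoro group makes no difference that can be told from scatter, as the step is a 1.2-fold higher number from compound 1 to compound 4 (0.08 log units; within the scatter).

The compounds shown leave open whether an ethyl group, a methoxy group or an amine on the same carbon would read like methyl or like hydrogen. They also leave open whether methyl gives a similar step when cyano stands in place of fluoro, as in compound 3.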